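The compounds below may be only part of what the source reports. "The series", "measured", "known", "first", "only" and "open" are said of these compounds alone.

Measured compounds:
compound 1 `CCCCCC(=O)N(NC(=O)c1cc(C)cc(C)c1)C(C)(C)C`, in an assay on cells for agonist activity at ecdysone receptor (Bombyx mori), read by a luciferase reporter, with a stated time of 24 h; a higher number here means that more compound is needed for the effect, a lower number that less compound is needed: 8710 nM
compound 2 `Cc1cc(C)cc(C(=O)NN(C(=O)CCC(C)C)C(C)(C)C)c1`, in this assay: 14500 nM
compound 3 `CCCCCC(=O)N(NC(=O)c1ccc(CC)cc1)C(C)(C)C`, in this assay: 2820 nM

Compounds 1 and 2 share a core and differ only in the acyl chain: isopropyl in place of propyl on a saturated chain carbon, two bonds along the chain from a carbonyl carbon. The step of a 1.7-fold higher number from compound 1 to compound 2 (0.22 log units; within the scatter) is small, and the two values cannot be ordered on this basis. Compound 3 carries a different core; how the core of compound 3 differs from the core of compound 1 is not broken down here, the two structures stand above. Compound 3 gives the lowest number of the three, and its separation from compound 1 and from compound 2 lies beyond the scatter.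

Compound 4 `CCc1ccc(C(=O)NN(C(=O)CCC(C)C)C(C)(C)C)cc1` has not yet been measured in this assay. It relates to compound 3 as compound 2 relates to compound 1, the same change at the same place: isopropyl in place of propyl on a saturated chain carbon, two bonds along the chain from a carbonyl carbon. Going by the values given here, the only measured instance of this change is a 1.7-fold higher number from compound 1 to compound 2 (0.22 log units; within the scatter), which did not move the value beyond the scatter. With one instance on one core, carrying it over to the core of compound 3 is the only basis available, and the expected step for compound 4 is therefore a 1.7-fold higher number from compound 3 to compound 4 (0.22 log units; within the scatter), close to the earlier one and of small size. On that basis compound 4 is estimated at 4700 nM in this assay, with a plausible range from 2000 nM to 11000 nM, the width reflecting that the change has been seen only once.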

Compound 4, half-maximal effective concentration: 832 nM
Estimate against measurement, compound 4: 5.6-fold (0.75 log units) above; measured number below the stated range.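

In this assay, isopropyl in place of propyl on the saturated chain carbon, two bonds along the chain from a carbonyl carbon, gives a 3.4-fold lower number from compound 3 to compound 4 (0.53 log units; beyond the scatter), and this step does not match the earlier one: the same change on two cores in this assay, a 1.7-fold higher number (0.22 log units; within the scatter) from compound 1 to compound 2 and a 3.4-fold lower number (0.53 log units; beyond the scatter) from compound 3 to compound 4, 5.6-fold (0.75 log units) apart, beyond the scatter of two such steps For these two cores, then, the step seen on one core did not carry over to the other in either size or direction, so a value for this change cannot simply be transferred between cores in this series. This does not show which feature of the cores sets the outcome, nor how general the difference is, as it rests on a single pair of compounds per core and the two cores are not broken down into separate changes.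

Going by these compounds, it remains open whether a third core would behave like the core of compound 1, like the core of compound 3, or like neither. Also open, on these data alone, is how the same two cores respond to other acyl chains, such as a longer chain or one ending in a cyclopentyl group, and whether a methoxy group or a chlorine on the core alters the result.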